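The source may report more compounds than this note shows. Statements on the series, on what has been measured and on what is new or still open speak of the compounds shown alone.

Measured compounds:
- Compound 1, `O=C(CSc1ncccn1)N/N=c1/scc(-c2ccc(Br)cc2)n1-c1ccccc1`, 76.4%
- Compound 2, `Cn1nnnc1SCC(=O)N/N=c1/scc(-c2ccc([N+](=O)[O-])cc2)n1-c1ccccc1`, 80.4%

Both were tested in a functional assay on C6 cells (Rattus norvegicus) for cytotoxicity, read by MTT assay, with a stated time of 24 h, tested at 6 ug/mL; a lower number here means a stronger effect, a higher number a weaker effect of the compound at the concentration tested. Compound 1 gives 76.4%, and compound 2 gives 80.4%; these two numbers lie within the usual scatter of each other, so neither compound stands apart from the other, and both leave most of the cells alive.

Compound 3, `Cn1nnnc1SCC(=O)N/N=c1/scc(-c2ccccc2)n1-c1ccccc1`, has not yet been measured. It differs from compound 2 in one place: hydrogen in place of nitro on an aromatic carbon. For the measured compounds named here, no pair of measured compounds shows what such a change does here, so the size of its step is unknown. Because compound 2 gives 80.4% and compound 1 gives 76.4%, two numbers within the scatter of each other, the expectation for compound 3 is a number close to that of compound 2, with an expected step of a number 1.6 percentage points higher from compound 2 to compound 3 (within the scatter) that stays within the scatter. Compound 3 is therefore expected to give about 82%, within a range from 68% to 96%.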

Compound 3, a percentage reported as activity, at one concentration (the size of the read-out at that concentration, not a potency): 85.2%
For compound 3 the middle estimate is 3.2 percentage points below the measured one; low and high end bracket the measured number.
By their numbers in this assay, from the lowest: compounds 1, 2 and 3 (each within the scatter of the next).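

For the compounds shown here, replacing the nitro group with a hydrogen atom, which turns 4-nitrophenyl into phenyl, gives the first direct reading of this position in this assay: a number 4.8 percentage points higher from compound 2 to compound 3 (within the scatter). On this pair, the numbers cannot be told apart, so the 3 heavy atoms of the nitro group can be taken away from the six-membered aromatic ring without a measurable difference in this read-out. Nothing available here accounts for this result or ties it to a property of the group.

As far as these compounds go, whether another group at this place, such as an amine, a methoxy group or a carboxylic acid, would give a number clearly apart from these remains open. From the compounds shown here alone, it is also open whether 4-nitrophenyl to phenyl would read the same with a different group elsewhere on the molecule.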